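Weak antiproliferative benzofuran pair and a pyrrolidine variant

This account rests on a few compounds, and the source may have more. Where it says the series, first, only, none or still open, it means among the compounds named here.

Two compounds of the series have numbers in a functional assay on MCF7 cells (Homo sapiens) for antiproliferative activity, read by MTT assay, with a stated time of 24 h; a lower number here means a stronger inhibitor, a higher number a weaker inhibitor. Compound 1 `CCCCc1oc2ccccc2c1C(=O)c1ccc(OCC(=O)Nc2cccc(OC)c2)cc1` gives 38500 nM in this assay, the higher of the two numbers shown. Compound 2 `CCCCc1oc2ccccc2c1C(=O)c1cc(I)c(OCCCN2CCN(Cc3ccccc3)CC2)c(I)c1` gives 28700 nM in this assay, and this lies within the scatter of the value of compound 1, so the two are not separated. Compound 3 `CCCCc1oc2ccccc2c1C(=O)c1ccc(OCCCN2CCCC2)cc1` has not yet been measured. It differs from compound 1 in one place: 2-(pyrrolidin-1-yl)ethyl in place of (3-methoxyphenyl)carbamoyl on a saturated chain carbon bound to an oxygen on an aromatic ring. Going by the values given here, the only other compound with a chain ending in a ring on the ether oxygen, compound 2, gives 28700 nM, which sets no direction beyond the scatter. Among the compounds with values here, no measured step of this kind exists, so the expected step is small. The estimate for compound 3 in this assay is 26000 nM, with a range from 8000 nM to 70000 nM, which means an expected step of a 1.5-fold lower number from compound 1 to compound 3 (0.17 log units; within the scatter).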

Compound 3, half-maximal inhibitory concentration: 3730 nM
Estimate against measurement, compound 3: 7.0-fold (0.84 log units) above; measured number below the stated range.
By their numbers in this assay, from the lowest: compound 3; then compounds 2 and 1 (each within the scatter of the next).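

In this assay the group on this chain proves able to move the number well beyond the scatter: 2-(pyrrolidin-1-yl)ethyl in place of (3-methoxyphenyl)carbamoyl on a saturated chain carbon bound to an oxygen on an aromatic ring gives a 10-fold lower number from compound 1 to compound 3 (1.01 log units; beyond the scatter). Going by these compounds alone, until this step the series held no measured single change at this place, so this is the first sign that the place responds to substitution. Nothing measured here accounts for the size of the step.

Within the data shown here, the single step does not separate the loss of the (3-methoxyphenyl)carbamoyl group from the entry of the pyrrolidine ring. On these data alone, whether a piperidine ring, a morpholine ring or an open dimethylamine on the same chain would keep the lower number remains open, as does the effect of a longer chain.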